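A few compounds are considered here, and "the series" means these few. Any claim that something is new, unique, unknown or untested is made for them only; others in the source may bear on it.

Compound 1 `Cc1[nH]ncc1-c1cncc(-c2ccc(C(N)=O)c(OC(C)C)c2)c1` gives 54 nM in an assay on cells for inhibition of MAP kinase-interacting serine/threonine-protein kinase 1 (Homo sapiens), read by mobility shift assay, with stated times of 10 min and 60 min, in the presence of a further agent that is not named here; on this read-out higher numbers stand for weaker inhibition and lower numbers for stronger inhibition.
Compound 2 `CNC(=O)c1cncc(-c2ccc(C(N)=O)c(OC(C)C)c2)c1` gives 1900 nM in this assay.

Among the compounds with values here, of the two measured compounds, compound 2 has the highest number, and the only other compound, compound 1, sits well below it: the single step of a 35-fold higher number from compound 1 to compound 2 (1.55 log units; beyond the scatter) is large and beyond the scatter. Compound 3 `CC(C)Oc1cc(-c2cncc(-c3nn[nH]n3)c2)ccc1C(N)=O` is made from compound 2 by 2H-tetrazol-5-yl in place of methylcarbamoyl on an aromatic carbon. Within the data shown here, the one step that bears on this change is the one from compound 1 to compound 2, where a five-membered aromatic ring with a hydrogen-bond donor was replaced by methylcarbamoyl and the number rose sharply. Compound 3 brings back a five-membered aromatic ring carrying a donor, so a sizeable fall in the number is expected, though not necessarily all the way to compound 1. Compound 3 is therefore estimated at 250 nM, in the range 50 nM to 1300 nM, a step of a 7.6-fold lower number from compound 2 to compound 3 (0.88 log units; beyond the scatter).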

Compound 3, half-maximal inhibitory concentration: 310 nM
Compound 3: the middle estimate sits 1.2-fold (0.09 log units) below what was measured; low and high end bracket the measured number.
By their numbers in this assay, from the lowest: compound 1; then compound 3; then compound 2.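

In this assay, swapping methylcarbamoyl for 2H-tetrazol-5-yl on this aromatic carbon gives a 6.1-fold lower number from compound 2 to compound 3 (0.79 log units; beyond the scatter) and so recovers part of the loss seen with methylcarbamoyl. Both five-membered aromatic rings shown here therefore beat methylcarbamoyl at this position, but they are not interchangeable: replacing 5-methyl-1H-pyrazol-4-yl with 2H-tetrazol-5-yl gives a 5.7-fold higher number from compound 1 to compound 3 (0.76 log units; beyond the scatter) and leaves a clear gap. No measurement is available to explain why these three groups rank as they do.

The two rings differ both in their hetero atoms and in the methyl group, so the compounds shown cannot say which of these accounts for that gap. A plain 1H-pyrazol-4-yl group would help separate the two, while a carboxylic acid or an amine at this position remains an open case.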